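The source may report more compounds than this note shows. Statements on the series, on what has been measured and on what is new or still open speak of the compounds shown alone.

Notes on the series. The shared core of compound 1 `C#CCSc1nc(Nc2ccccc2Cl)c2ccncc2n1` carries a chloro-substituted anilino group and a propargyl thioether; in a functional assay on HepG2 cells (Homo sapiens) for inhibition, read by MTT assay, with a stated time of 72 h (on this read-out higher numbers stand for weaker inhibition and lower numbers for stronger inhibition), compound 1 gives 17200 nM. Compound 2 `C#CCSc1nc(Nc2ccccc2O)c2ccncc2n1` keeps everything but has hydroxy in place of chloro on the aromatic carbon. In this assay compound 2 sits at a limit of the assay, > 80000 nM, which is the limit of > 80000 nM in this assay, at which 1 of the 3 values shown sits. The step of an at least 4.6-fold higher number from compound 1 to compound 2 (0.66 log units; beyond the scatter) is therefore at least modest and runs toward weaker inhibition. Compound 3 `CCCSc1nc(Nc2cccc(OC)c2)c2ccncc2n1` carries a methoxy-substituted anilino group and a propyl thioether; in this assay compound 3 gives 17300 nM, the highest of the two numbers shown, with compound 1 the nearest and within the scatter of it. The remaining value shown, that of compound 2, is a limit of the assay.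

Compound 4 `COc1cccc(Nc2nc(SCC3CCCCC3)nc3cnccc23)c1` differs from compound 3 by cyclohexyl in place of ethyl on a saturated chain carbon bound to a sulfur. Among the compounds with values here, none of the measured steps touches the thioether chain; the only measured step concerns the substituent on the anilino ring and cannot be carried over. Within the data shown here, with no step at this position to lean on, the change from compound 3 to compound 4 is expected to give a 1.2-fold lower number from compound 3 to compound 4 (0.06 log units; within the scatter), nothing beyond the scatter. In this assay compound 4 is estimated at 15000 nM, with a range from 4000 nM to 60000 nM.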

Compound 4, half-maximal inhibitory concentration: 32800 nM
Beside the measured number, compound 4's estimate is 2.2-fold (0.34 log units) below it, and the stated range covers the measured number.
By their numbers in this assay, from the lowest: compounds 1, 3 and 4 (each within the scatter of the next). At a limit, above all of these: compound 2.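

Within the data shown here, this is the first measured step on the thioether chain: cyclohexyl in place of ethyl on a saturated chain carbon bound to a sulfur gives a 1.9-fold higher number from compound 3 to compound 4 (0.28 log units; within the scatter) in this assay. Read as propyl to cyclohexylmethyl, the change brings in one six-membered non-aromatic ring of carbon only, yet this pair stays within the scatter, whereas the only step beyond it so far is the hydroxy in place of chloro change on the anilino ring, in a different pair. Nothing shown bears on why the step at the thioether chain has this size.

Going by these compounds, compounds 1 and 3 differ in two places, so the propargyl and propyl thioethers cannot be compared directly, and whether cyclohexylmethyl would read the same with a chloro-substituted anilino group remains open. Also open, on these data alone, is how this position would respond to a chain ending in an amine or a carboxylic acid, to a longer straight chain, or to a phenyl ring in place of cyclohexyl.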